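Swapping 6-chloropyridin-2-yl for 3-methylpyridin-2-yl

A few compounds are considered here, and "the series" means these few. Any claim that something is new, unique, unknown or untested is made for them only; others in the source may bear on it.

In an ADME assay on PBMC cells (Homo sapiens) for cytotoxicity (a higher number here means that more compound is tolerated, a lower number that less compound is tolerated), compound 1 (`CC(CCNC(=O)c1c(Cl)cncc1Cl)N1CCC(C(Oc2ncccc2Cl)c2ccc(C(F)(F)F)cc2)CC1`) gives 16700 nM. Compound 2 (`CC(CCNC(=O)c1c(Cl)cncc1Cl)N1CCC(C(Oc2cccc(Cl)n2)c2ccc(C(F)(F)F)cc2)CC1`) stands only at > 32500 nM, which is a limit of the assay and not a number. Among the measured compounds shown here, one measured step bears on what follows: an at least 1.9-fold higher number from compound 1 to compound 2 (0.28 log units; that floor lies within the scatter), with 6-chloropyridin-2-yl in place of 3-chloropyridin-2-yl on an oxygen on a saturated carbon. Compound 3 (`Cc1cccnc1OC(c1ccc(C(F)(F)F)cc1)C1CCN(C(C)CCNC(=O)c2c(Cl)cncc2Cl)CC1`) now carries 3-methylpyridin-2-yl in place of 6-chloropyridin-2-yl at that oxygen: 3-methylpyridin-2-yl in place of 6-chloropyridin-2-yl on an oxygen on a saturated carbon. Its group shares the 3-substituted pyridin-2-yl name with that of compound 1 at 16700 nM, so compound 1 serves as the nearest guide, and a move towards a lower number in this assay is expected. The expected change is an at least 1.6-fold lower number from compound 2 to compound 3 (0.21 log units; that floor lies within the scatter). Compound 3 is estimated at 20000 nM, with an expected range of 10000 nM to 35000 nM.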

Compound 3, half-maximal cytotoxic concentration: 33000 nM
For compound 3 the middle estimate is 1.7-fold (0.22 log units) below the measured one, within the range that was stated.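

In this assay, among the compounds shown here, methyl in place of chloro on an aromatic carbon gives a 2.0-fold higher number from compound 1 to compound 3 (0.30 log units; within the scatter), so this assay does not tell the two 3-substituted pyridin-2-yl groups apart, a comparison the earlier compounds did not offer. For compound 2, > 32500 nM is a limit of the assay and not a number, so the step from compound 2 to compound 3 cannot be read. Any comparison with compound 2 rests on that limit: the limit of > 32500 nM in this assay, at which 1 of the 3 values shown sits.

On these data alone, it remains open how far compound 2 lies from its limit, and so whether 6-chloropyridin-2-yl and 3-methylpyridin-2-yl differ at all at this oxygen. Also open, as far as these compounds go, is how a nitrile or an amine in place of the methyl of 3-methylpyridin-2-yl would read in this assay.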